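This account rests on a few compounds, and the source may have more. Where it says the series, first, only, none or still open, it means among the compounds named here.

Compound 2 `CC(C)NS(=O)(=O)c1ccc(S(=O)(=O)N2CCC[C@@H](C(=O)N3CCC(F)(F)CC3)C2)cc1` shares its core with compound 1 `CC(C)CS(=O)(=O)c1ccc(S(=O)(=O)N2CCC[C@@H](C(=O)N3CCC(F)(F)CC3)C2)cc1`. Within the data shown here, in a functional assay on MIA PaCa-2 cells (Homo sapiens) for inhibition, read by MTT assay, with a stated time of 7 days (a higher number here means a weaker inhibitor, a lower number a stronger inhibitor), compound 2 gives 350 nM, the higher of the two numbers measured so far, while in this assay compound 1 gives 80 nM. Among the measured compounds shown here, the single measured step, a 4.4-fold higher number from compound 1 to compound 2 (0.64 log units; beyond the scatter), came from putting isopropylamino in place of isobutyl on a sulfonyl sulfur. Compound 3 `CN(C)S(=O)(=O)c1ccc(S(=O)(=O)N2CCC[C@@H](C(=O)N3CCC(F)(F)CC3)C2)cc1` differs from compound 2 by dimethylamino in place of isopropylamino on a sulfonyl sulfur. This change keeps an amino group on the sulfonyl sulfur and only swaps the carbons attached to its nitrogen, so the measured step bears on it loosely: it shows that the group on the sulfonyl sulfur can move the number by a modest amount, but nothing measured separates one amino group from another. The expected step is therefore small, a 1.2-fold lower number from compound 2 to compound 3 (0.07 log units; within the scatter), in no firm direction. Compound 3 is estimated at 300 nM, with a range from 100 nM to 900 nM.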

Compound 3, half-maximal inhibitory concentration: 118 nM
Estimate against measurement, compound 3: 2.5-fold (0.41 log units) above; measured number inside the range.
By their numbers in this assay, from the lowest: compounds 1 and 3 (each within the scatter of the next); then compound 2.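

In this assay, amino groups on the sulfonyl sulfur are not interchangeable: the step of a 3.0-fold lower number from compound 2 to compound 3 (0.47 log units; beyond the scatter) shows that swapping isopropylamino for dimethylamino can matter, whereas the earlier pair compared only an amino group with isobutyl. The step of a 1.5-fold higher number from compound 1 to compound 3 (0.17 log units; within the scatter) adds that an amino group at this place need not give a number distinguishable from that of isobutyl, so the earlier loss from compound 1 to compound 2 does not apply to amino groups in general. Isopropylamino counts one hydrogen-bond donor and dimethylamino none, but no measurement available here ties the difference in numbers to this or to any other feature.

The compounds shown leave open whether that donor or the carbons on the nitrogen set the number. Methylamino, plain amino and diethylamino would help separate those two readings.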